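Bromo for iodo on the anilino ring of compound 2

This account rests on a few compounds, and the source may have more. Where it says the series, first, only, none or still open, it means among the compounds named here.

Compound 1, `Cc1ccc(NC2=C(C(=O)c3ccccc3)C(c3ccc(Br)cc3)N(CCCn3ccnc3)C2=O)cc1` — in a functional assay on SAOS-2 cells (Homo sapiens) for antiproliferative activity, read by MTT assay, with a stated time of 72 h (a lower number here means a stronger inhibitor, a higher number a weaker inhibitor), compound 1 gives 31900 nM.
Compound 2, `O=C(C1=C(Nc2ccc(I)cc2)C(=O)N(CCCn2ccnc2)C1c1ccc(Br)cc1)c1ccccc1` — in this assay compound 2 gives 23400 nM.

For the measured compounds named here, compound 2 holds the lowest of the two numbers measured, but its only neighbour, compound 1, sits within the scatter of it: a 1.4-fold lower number from compound 1 to compound 2 (0.13 log units; within the scatter). Compound 3, `O=C(C1=C(Nc2ccc(Br)cc2)C(=O)N(CCCn2ccnc2)C1c1ccc(Br)cc1)c1ccccc1`, differs from compound 2 in one place: bromo in place of iodo on an aromatic carbon. Going by the values given here, no measured step exchanges one halogen for another; the single step known, from a methyl to an iodo at the same place, moved nothing beyond the scatter. On that basis no step beyond the scatter is expected in this assay, in either direction, and the step from compound 2 to compound 3 is estimated as a 1.1-fold higher number from compound 2 to compound 3 (0.05 log units; within the scatter). Compound 3 is therefore expected to give 26000 nM, within a range of 12000 nM to 55000 nM.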

Compound 3, half-maximal inhibitory concentration: 23800 nM
Beside the measured number, compound 3's estimate is 1.1-fold (0.04 log units) above it; low and high end bracket the measured number.
By their numbers in this assay, from the lowest: compounds 2, 3 and 1 (each within the scatter of the next).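

In this assay, for the compounds shown here, this is the first exchange of one halogen for another at this place, and it gives a 1.0-fold higher number from compound 2 to compound 3 (0.01 log units; within the scatter), so the 4-iodophenyl and 4-bromophenyl compounds cannot be told apart. The step of a 1.3-fold lower number from compound 1 to compound 3 (0.13 log units; within the scatter) gives a second replacement of the methyl that stays within the scatter, so methyl, iodo and bromo on this aromatic carbon read alike across these three compounds. No available evidence bears on this result. On these data alone, whether a group of another kind at this place, such as an amine, a carboxylic acid or a methoxy group, would give a step beyond the scatter remains open. Also open, as far as these compounds go, is whether changes elsewhere on the shared core would move the number further than these exchanges on the anilino ring.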